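Swapping the fluorophenyl on the alkyne for a pyridinyl

The source may hold more compounds than are shown below. What is called first, only, known or untested is meant among the compounds shown, and "the series" means these compounds.

Measured compounds:
compound 1, `CNC(=O)[C@@]12C[C@@H]1[C@@H](n1cnc3c(NC)nc(C#Cc4ccccc4F)nc31)[C@H](O)[C@@H]2O`, 20%
compound 2, `CNC(=O)[C@@]12C[C@@H]1[C@@H](n1cnc3c(NC)nc(C#Cc4ccc(F)cc4)nc31)[C@H](O)[C@@H]2O`, 27%
compound 3, `CNC(=O)[C@@]12C[C@@H]1[C@@H](n1cnc3c(NC)nc(C#Cc4ccc(CO)cc4)nc31)[C@H](O)[C@@H]2O`, 16%

All three compounds were tested in an assay on CHO cells for displacement of a labelled ligand from adenosine receptor A1 (Homo sapiens), read by scintillation counting, with a stated time of 60 min, tested at 10 uM; on this read-out lower numbers stand for less inhibition and higher numbers for more inhibition at the one concentration tested (going by the name of the read-out). Among them, compound 1 stands second highest, though its number is within the scatter of both compound 2 (a number 7 percentage points higher from compound 1 to compound 2 (within the scatter)) and compound 3 (a number 4 percentage points lower from compound 1 to compound 3 (within the scatter)). Only the gap between compound 2 and compound 3 (a number 11 percentage points lower from compound 2 to compound 3 (beyond the scatter)) goes beyond the scatter, and modestly so.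

Compound 4, `CNC(=O)[C@@]12C[C@@H]1[C@@H](n1cnc3c(NC)nc(C#Cc4cccnc4)nc31)[C@H](O)[C@@H]2O`, has not yet been measured. It differs from compound 1 in one place: pyridin-3-yl in place of 2-fluorophenyl on a triple-bonded carbon. Both measured steps from compound 1 change the same group on the triple-bonded carbon, and neither moved the number beyond the scatter. A further exchange of that group is therefore expected to leave the inhibition much where compound 1 sits. The step from compound 1 to compound 4 is estimated at no change at the digits printed from compound 1 to compound 4 (within the scatter). Compound 4 is expected to give about 20%, with a range from 8% to 32%.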

Compound 4, a percentage reported as inhibition, at one concentration (the size of the read-out at that concentration, not a potency): 16%
Compound 4: the middle estimate sits 4 percentage points above what was measured, and the stated range covers the measured number.
By their numbers in this assay, from the lowest: compounds 3, 4, 1 and 2 (each within the scatter of the next, the first and the last beyond it).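

In this assay, pyridin-3-yl on the triple-bonded carbon gives a number 4 percentage points lower from compound 1 to compound 4 (within the scatter) and no change at the digits printed from compound 3 to compound 4 (within the scatter), so a ring with a hetero atom, here nitrogen, gives a number within the scatter of both the 2-fluorophenyl and the 4-(hydroxymethyl)phenyl compounds. Going by these compounds alone, the one new step beyond the scatter is a number 11 percentage points lower from compound 2 to compound 4 (beyond the scatter), which is modest and the same size as a number 11 percentage points lower from compound 2 to compound 3 (beyond the scatter). No measurement shown explains why these steps are small or why compound 2 stands apart from compounds 3 and 4.

Still open, on these data alone, is whether an amine or a carboxylic acid on the ring, or a longer chain in its place, would move the number beyond the scatter from compound 1. Within the data shown here, with only one concentration per compound, these numbers also leave potency unknown.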